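Swapping the amine substituent on the piperidine ring

The compounds below may be only part of what the source reports. "The series", "measured", "known", "first", "only" and "open" are said of these compounds alone.

Measured compounds:
compound 1 `COC[C@H](NC1CCN(CCCc2c[nH]c3ccc(Cn4cncn4)cc23)CC1)c1ccc(F)cc1`: 1200 nM
compound 2 `CN(Cc1ccc(S(C)(=O)=O)cc1)C1CCN(CCCc2c[nH]c3ccc(-n4cnnc4)cc23)CC1`: 140 nM
compound 3 `CC(C)=CCCN(C)C1CCN(CCCc2c[nH]c3ccc(-n4cnnc4)cc23)CC1`: 24 nM

In an assay on CHO cells for displacement of a labelled ligand from 5-hydroxytryptamine receptor 1B (Homo sapiens) (on this read-out lower numbers stand for stronger inhibition and higher numbers for weaker inhibition), compound 3 gives 24 nM, the lowest number of the three and therefore the strongest inhibition seen so far. Compound 2 gives 140 nM and compound 1 gives 1200 nM in this assay, both clearly higher.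

Compound 4 `C[C@@H](NCC1CCN(CCCc2c[nH]c3ccc(-n4cnnc4)cc23)CC1)c1ccccc1` has not yet been measured. It differs from compound 3 in one place: ((1-phenylethyl)amino)methyl in place of methyl(4-methylpent-3-en-1-yl)amino on a saturated ring carbon. The group that leaves carries no ring and a double bond; the group that enters carries a six-membered aromatic ring of carbon only, one hydrogen-bond donor and a defined stereocentre.

Within the data shown here, only one measured step bears on this change. The step of a 5.8-fold lower number from compound 2 to compound 3 (0.77 log units; beyond the scatter) shows that replacing an aromatic-ring-bearing group on the amine by a branched open chain with a double bond lowered the number. Compound 4 goes the other way, bringing an aromatic ring back onto the amine, so the number is expected to rise again, by a modest amount beyond the scatter. The estimated step is a 4.2-fold higher number from compound 3 to compound 4 (0.62 log units; beyond the scatter). In this assay compound 4 is therefore expected to give about 100 nM, within a range of 30 nM to 350 nM.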

Compound 4, half-maximal inhibitory concentration: 14 nM
Estimate against measurement, compound 4: 7.1-fold (0.85 log units) above, outside the stated range (below it).
By their numbers in this assay, from the lowest: compounds 4 and 3 (each within the scatter of the next); then compound 2; then compound 1.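

In this assay, the exchange of the open chain for the aromatic group gives a 1.7-fold lower number from compound 3 to compound 4 (0.23 log units; within the scatter), so the two compounds cannot be told apart on this read-out. The earlier step, a 5.8-fold lower number from compound 2 to compound 3 (0.77 log units; beyond the scatter), therefore does not carry over to every group with an aromatic ring: here, a ((1-phenylethyl)amino)methyl group on this saturated ring carbon reads no differently from the methyl(4-methylpent-3-en-1-yl)amino group it replaces. No measurement shown explains why these two different groups cannot be told apart.

The aromatic ring, the hydrogen-bond donor and the defined stereocentre all enter in one change, and the amine nitrogen also sits within a different group, leaving the contribution of each feature unresolved. A (benzylamino)methyl group, which lacks the methyl at the stereocentre, or a ((1-cyclohexylethyl)amino)methyl group, which has a saturated ring in place of the aromatic one, would help separate these features, but the compounds shown do not reveal how either would read.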